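Swapping the seven-membered ring for a methoxy-bearing six-membered ring

The source may report more compounds than this note shows. Statements on the series, on what has been measured and on what is new or still open speak of the compounds shown alone.

Measured so far:
Compound 1, `O=C(N1CCC(F)CC1)N1CC(c2nc(-c3cccc(Cl)c3)no2)C1`: 990 nM
Compound 2, `O=C(N1CCCCCC1)N1CC(c2nc(-c3cccc(Cl)c3)no2)C1`: 47 nM

Both compounds share one core and differ only in the ring attached to the carbonyl carbon. In an assay on HEK293 cells for positive allosteric modulation of metabotropic glutamate receptor 5 (Homo sapiens), read by FLIPR (a higher number here means that more compound is needed for the effect, a lower number that less compound is needed), compound 1 gives 990 nM, and compound 2 gives 47 nM. Among the compounds with values here, compound 2 therefore stands at the lowest of the two numbers, and the single step connecting them, a 21-fold lower number from compound 1 to compound 2 (1.32 log units; beyond the scatter), is large and clearly beyond the scatter.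

Compound 3, `COC1CCN(C(=O)N2CC(c3nc(-c4cccc(Cl)c4)no3)C2)CC1`, is not yet measured. It differs from compound 2 in one place: 4-methoxypiperidin-1-yl in place of azepan-1-yl on a carbonyl carbon. This change partly reverses the step from compound 1 to compound 2, since a six-membered ring with a single group on it returns to the carbonyl carbon, though the group is methoxy rather than fluorine. Within the data shown here, the only step that bears on the question is a 21-fold lower number from compound 1 to compound 2 (1.32 log units; beyond the scatter), which moved in the other direction. On that basis, the number for compound 3 is expected to rise again in this assay, by roughly an 11-fold higher number from compound 2 to compound 3 (1.03 log units; beyond the scatter), landing nearer to compound 1 than to compound 2. The estimate for compound 3 is 500 nM, with a range from 150 nM to 2000 nM.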

Compound 3, half-maximal effective concentration: > 10000 nM
Compound 3 gave a limit, no number (the forecaster's own chance of this, stated with the estimate: 5%); at least 20-fold (1.30 log units) between middle value and limit.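

In this assay compound 3 is recorded only as a limit of the assay, not as a number: the limit of > 10000 nM in this assay, at which 1 of the 3 values shown sits. Putting 4-methoxypiperidin-1-yl in place of azepan-1-yl on the carbonyl carbon gives an at least 210-fold higher number from compound 2 to compound 3 (2.32 log units; beyond the scatter), so this position responds to the ring on the carbonyl far more sharply than the first pair alone could show. Comparing the two six-membered rings, methoxy in place of fluoro on a saturated ring carbon gives an at least 10-fold higher number from compound 1 to compound 3 (1.00 log units; beyond the scatter), which shows that the group carried on the ring counts here as well, and that the move away from the seven-membered ring does not by itself fix the result.

As far as these compounds go, how much of the loss belongs to the change of ring and how much to the group on it stays open, and a plain piperidin-1-yl, with nothing on the ring, would separate the two. From the compounds shown here alone, whether the oxygen of the methoxy matters also stays open, and a simple ethyl group on the same ring carbon, which has no oxygen, would speak to that.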